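Series notes: cyclobutyl to aminomethyl exchange on compound 2

The source may hold more compounds than are shown below. What is called first, only, known or untested is meant among the compounds shown, and "the series" means these compounds.

Compound 1 `Fc1ccccc1Cn1nc(-c2ccco2)c2cccnc21` in a functional assay (aorta) with Oryctolagus cuniculus as the target (on this read-out lower numbers stand for stronger inhibition and higher numbers for weaker inhibition), gives 9300 nM. Among the compounds with values here, compound 2 `Nc1nc(-c2nn(Cc3ccccc3F)c3ncccc23)ncc1C1CCC1` gives in this assay 633000 nM, the highest of the two numbers measured so far; the nearest number is that of compound 1, and the gap between the two lies beyond the scatter. Compound 3 `NCc1cnc(-c2nn(Cc3ccccc3F)c3ncccc23)nc1N` has not yet been measured. It differs from compound 2 in one place: aminomethyl in place of cyclobutyl on an aromatic carbon. Within the data shown here, no step between measured compounds shows what an exchange of this kind does in this assay, and compound 2 is the only measured compound that carries this core, so the expectation rests on compound 2 alone. The step of a 1.6-fold lower number from compound 2 to compound 3 (0.20 log units; within the scatter) is therefore expected to be small, with no direction claimed beyond the scatter. Compound 3 is estimated at 400000 nM, within a range from 80000 nM to 2000000 nM, the width reflecting the absence of any comparable step.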

Compound 3, half-maximal inhibitory concentration: 1400000 nM
Estimate against measurement, compound 3: 3.5-fold (0.54 log units) below, within the range that was stated.
By their numbers in this assay, from the lowest: compound 1; then compound 2; then compound 3.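

Notes on the position ortho to an amino group: in this assay, aminomethyl in place of cyclobutyl gives a 2.2-fold higher number from compound 2 to compound 3 (0.34 log units; beyond the scatter), the first step read at this place, modest in size and beyond the scatter. The exchange removes the four-membered carbon ring and brings in a hydrogen-bond donor and acceptor, and the number moves only modestly, so this one exchange does not change the read-out by much. Nothing measured on these compounds accounts for the step.

Going by these compounds, this single exchange changes ring, size and amine together, so the share of each stays open. A methyl, a cyclopropyl or a hydroxymethyl at this carbon, or a longer chain such as aminoethyl, would separate these contributions.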